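The source may hold more compounds than are shown below. What is called first, only, known or untested is meant among the compounds shown, and "the series" means these compounds.

Compound 1 `O=S(=O)(N/C(=N\O)Nc1ccc(Cl)cc1)c1ccccc1`: 53 ug/mL
Compound 2 `O=S(=O)(N/C(=N\O)Nc1ccc(Cl)cc1)c1cccc2snnc12`: 87 ug/mL
Compound 3 `O=[N+]([O-])c1ccc(Oc2c(Cl)cc(S(=O)(=O)N/C(=N\O)Nc3ccc(Cl)cc3)cc2Cl)cc1`: 12 ug/mL

All three compounds were tested in a functional assay on COLO 205 cells (Homo sapiens) for cytotoxicity; on this read-out higher numbers stand for weaker inhibition and lower numbers for stronger inhibition. Compound 3 gives the lowest number of the three at 12 ug/mL, and its gaps to both compound 1 and compound 2 lie beyond the scatter.

The next compound, compound 4 `O=[N+]([O-])c1ccc(Oc2c(Cl)cc(S(=O)(=O)N/C(=N\O)Nc3ccc(Cl)cc3)cc2Cl)c(Cl)c1`, has not yet been measured in this assay. It differs from compound 3 by one change: chloro in place of hydrogen on an aromatic carbon. The chloro sits on an aromatic carbon, ortho to a large group and meta to a nitro group, so that 4-nitrophenoxy becomes 2-chloro-4-nitrophenoxy.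

Among the compounds with values here, no measured pair of compounds shows this change, so the data offer no direct guide to its size. The expectation therefore starts from compound 3 at 12 ug/mL, and no step beyond the scatter is expected. The estimated change, a 1.2-fold lower number from compound 3 to compound 4 (0.08 log units; within the scatter), is small and leans slightly towards a lower number. For compound 4 the expected value is 10 ug/mL, with an estimated range of 5 ug/mL to 22 ug/mL.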

Compound 4, half-maximal inhibitory concentration: 6 ug/mL
The estimate for compound 4 lay 1.7-fold (0.22 log units) above the measured number, within the range that was stated.
By their numbers in this assay, from the lowest: compounds 4 and 3 (each within the scatter of the next); then compounds 1 and 2 (each within the scatter of the next).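

In this assay the change from 4-nitrophenoxy to 2-chloro-4-nitrophenoxy gives a 2.0-fold lower number from compound 3 to compound 4 (0.30 log units; within the scatter) and is the first reading of chloro in place of hydrogen among these compounds. It shows that this aromatic carbon, ortho to a large group and meta to a nitro group, can carry a chloro with no step beyond the scatter in this cytotoxicity read-out. No measurement at hand bears on the reason for this result.

On these data alone, what a bromo, a methyl or a methoxy group would give on the same carbon remains open. As far as these compounds go, it also remains open whether chloro would give a similar step with an amine in place of the nitro group.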